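From a fluorinated side chain to a longer carbon chain

The compounds below may be only part of what the source reports. "The series", "measured", "known", "first", "only" and "open" are said of these compounds alone.

Measured in a functional assay on HeLa cells (Homo sapiens) for cytotoxicity, read by WST assay, with a stated time of 48 h; on this read-out lower numbers stand for stronger inhibition and higher numbers for weaker inhibition:
- Compound 1 `COc1cc(C(c2ccc(O)c(OC)c2)[C@@H](C)[C@@H](C)CO)ccc1O`: > 100000 nM (a limit of the assay, not a number)
- Compound 2 `COc1cc(C(c2ccc(O)c(OC)c2)[C@@H](C)C(C)C)ccc1O`: 19000 nM
- Compound 3 `COc1cc(C(c2ccc(O)c(OC)c2)[C@@H](C)[C@H](C)CF)ccc1O`: 37000 nM

Compound 1 reads > 100000 nM, and this is only a limit. For the measured compounds named here, compound 3 gives 37000 nM, which cannot be told apart from the only other exact number in this assay, since a 1.9-fold higher number from compound 2 to compound 3 (0.29 log units; within the scatter).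

The next compound, compound 4 `CCCCC[C@H](C(C)C)C(c1ccc(O)c(OC)c1)c1ccc(O)c(OC)c1`, has not been measured yet. The change is 1-isopropylhexyl in place of 2-(fluoromethyl)-1-methylpropyl on a saturated chain carbon bound to two aromatic carbons, so 1-isopropylhexyl replaces 2-(fluoromethyl)-1-methylpropyl on a saturated chain carbon bound to two aromatic carbons.

Going by the values given here, three measured steps bear on this. Removing the hydroxy gave an at least 5.2-fold lower number from compound 1 to compound 2 (0.72 log units; beyond the scatter), and replacing it with fluoro gave an at least 2.7-fold lower number from compound 1 to compound 3 (0.43 log units; beyond the scatter). Both were at least modest, while the swap between hydrogen and fluoro stayed within the scatter. Among the compounds with values here, neither group in the new change carries a hydroxy, so these steps guide it only loosely, and no measured compound has a chain as long as 1-isopropylhexyl. Compound 2, at 19000 nM, is the nearest guide, so a modest move towards lower numbers is expected. The expected change is a 2.5-fold lower number from compound 3 to compound 4 (0.39 log units; beyond the scatter). Compound 4 is estimated at 15000 nM, with an expected range from 4000 nM to 50000 nM.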

Compound 4, half-maximal inhibitory concentration: 9200 nM
For compound 4 the middle estimate is 1.6-fold (0.21 log units) above the measured one; measured number inside the range.
By their numbers in this assay, from the lowest: compound 4; then compounds 2 and 3 (each within the scatter of the next). At a limit, above all of these: compound 1.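

At this place, on a saturated chain carbon bound to two aromatic carbons, 1-isopropylhexyl gives the first differences beyond the scatter among compounds that lack a hydroxy: in this assay there is a 4.0-fold lower number from compound 3 to compound 4 (0.60 log units; beyond the scatter), and also a 2.1-fold lower number from compound 2 to compound 4 (0.31 log units; beyond the scatter). The earlier swap between hydrogen and fluoro could not separate compound 2 from compound 3, so this result shows that a larger change to the side chain can move the number, although 1-isopropylhexyl has more heavy atoms, no fluorine and one defined stereocentre, which means that chain length cannot be singled out. Compound 1 is held at a limit and not a number, so the step to it reads as an at least 10-fold lower number from compound 1 to compound 4 (1.03 log units; beyond the scatter), and that limit is the only one in the set: the limit of > 100000 nM in this assay, at which 1 of the 4 values shown sits.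

With a single long chain shown, the compounds leave open whether a shorter chain such as 1-isopropylpropyl or a still longer chain would give a lower or higher number. They also leave open how an amine or a carboxylic acid at the end of the chain would read in this assay.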